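A few compounds are considered here, and "the series" means these few. Any claim that something is new, unique, unknown or untested is made for them only; others in the source may bear on it.

Measured in a functional assay on A549 cells (Homo sapiens) for cytotoxicity, read by MTT assay, with a stated time of 72 h; on this read-out higher numbers stand for weaker inhibition and lower numbers for stronger inhibition:
Compound 1 `CN(C)CCn1cnnc1-c1cc(Oc2ccc(NC(=O)N/N=C/c3ccc(Cl)cc3Cl)cc2F)ccn1` gives 810 nM.
Compound 2 `CN(C)CCn1cnnc1-c1cc(Oc2ccc(NC(=O)N/N=C/c3c(Cl)cccc3Cl)cc2F)ccn1` gives 1410 nM.
Compound 3 `COc1ccc(OC)c(/C=N/NC(=O)Nc2ccc(Oc3ccnc(-c4nncn4CCN(C)C)c3)c(F)c2)c1` gives 1950 nM.

Compound 3 stands clearly apart only from compound 1, since a 2.4-fold higher number from compound 1 to compound 3 (0.38 log units; beyond the scatter), whereas its separation from compound 2 is slight, since a 1.4-fold higher number from compound 2 to compound 3 (0.14 log units; within the scatter). Compound 4 `CN(C)CCn1cnnc1-c1cc(Oc2ccc(NC(=O)N/N=C/c3ccc(O)c(O)c3)cc2F)ccn1` has not yet been measured in this assay. It differs from compound 3 in one place: 3,4-dihydroxyphenyl in place of 2,5-dimethoxyphenyl on a carbon with a double bond to nitrogen. Among the measured compounds shown here, no measured step brings in a dihydroxyphenyl, so the aryl exchanges among compounds 1, 2 and 3 are the only guide; those moved the number by a 1.7-fold higher number from compound 1 to compound 2 (0.24 log units; within the scatter), a 2.4-fold higher number from compound 1 to compound 3 (0.38 log units; beyond the scatter) and a 1.4-fold higher number from compound 2 to compound 3 (0.14 log units; within the scatter), all small. A small step with no clear direction is therefore expected for compound 4, which is estimated at 2200 nM with a range from 700 nM to 7000 nM, meaning a 1.1-fold higher number from compound 3 to compound 4 (0.05 log units; within the scatter).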

Compound 4, half-maximal inhibitory concentration: > 100000 nM
Compound 4: no number, only a limit; the forecaster's own chance of this, stated with the estimate: 5%; middle value at least 45-fold (1.65 log units) from the limit.
By their numbers in this assay, from the lowest: compounds 1, 2 and 3 (each within the scatter of the next, the first and the last beyond it). At a limit, above all of these: compound 4.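

Compound 4 carries a limit of the assay rather than a number: the limit of > 100000 nM in this assay, at which 1 of the 4 values shown sits.

The earlier exchanges on a carbon with a double bond to nitrogen stayed small, but bringing in 3,4-dihydroxyphenyl opens far larger steps: an at least 51-fold higher number from compound 3 to compound 4 (1.70 log units; beyond the scatter) and an at least 70-fold higher number from compound 2 to compound 4 (1.85 log units; beyond the scatter) and an at least 120-fold higher number from compound 1 to compound 4 (2.09 log units; beyond the scatter) in this assay. This position is therefore not indifferent to the aryl group, and the entering group carries hydrogen-bond donors where the three earlier groups carry none.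

From the compounds shown here alone, whether 3,4-dimethoxyphenyl or a phenyl with a single hydroxyl group would stay near compounds 1, 2 and 3 remains open. The loss therefore cannot yet be assigned to the hydroxyl groups themselves or to their placement on the ring.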